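From Compound 1 to Compound 4: Swapping the Amine

A few compounds are considered here, and "the series" means these few. Any claim that something is new, unique, unknown or untested is made for them only; others in the source may bear on it.

Measured compounds:
- compound 1 `CC[C@H](C)Nc1nc(Cl)nc(N[C@@H](C)c2ccccc2)n1`, 14100 nM
- compound 2 `CC[C@H](C)Nc1nc(Cl)nc(N[C@H](C)c2ccccc2)n1`, 52500 nM
- compound 3 `CC[C@@H](C)Nc1nc(Cl)nc(N[C@H](C)c2ccccc2)n1`, 4570 nM

The three measured compounds were tested in an ADME assay on the whole organism for inhibition, with Echinochloa crus-galli var. formosensis as the target, with a stated time of 4 days; on this read-out higher numbers stand for weaker inhibition and lower numbers for stronger inhibition. Compound 1 stands second highest of the three numbers: compound 3 lies a 3.1-fold lower number from compound 1 to compound 3 (0.49 log units; beyond the scatter), and compound 2 lies a 3.7-fold higher number from compound 1 to compound 2 (0.57 log units; beyond the scatter). Between the other two, the step runs an 11-fold lower number from compound 2 to compound 3 (1.06 log units; beyond the scatter). All three steps are changes of configuration only the fact that compounds 1 and 2 differ only in the configuration as drawn the fact that compounds 1 and 3 differ only in the configuration as drawn (the fact that compounds 2 and 3 differ only in the configuration as drawn).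

Compound 4 `CCCN(CCC)c1nc(Cl)nc(N[C@@H](C)c2ccccc2)n1` differs from compound 1 in another way: dipropylamino in place of (sec-butyl)amino on an aromatic carbon. Among the compounds with values here, none of the measured steps bears on this change, since each of them concerns configuration alone while compound 4 alters the group itself. Within the data shown here, the data therefore give no direction for the step, and the expectation for compound 4 is simply that it remains in the region of compound 1, with a wide range. The estimated step is a 1.4-fold higher number from compound 1 to compound 4 (0.15 log units; within the scatter). Compound 4 is thus expected to give 20000 nM, within 4000 nM to 100000 nM.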

Compound 4, half-maximal inhibitory concentration: 100 nM
The estimate for compound 4 lay 200-fold (2.30 log units) above the measured number, and the stated range ends above it.
By their numbers in this assay, from the lowest: compound 4; then compound 3; then compound 1; then compound 2.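

Within the data shown here, the position between two ring nitrogen atoms, so far seen only with (sec-butyl)amino in its two configurations, responds far more to a change of the group itself: in this assay the step is a 140-fold lower number from compound 1 to compound 4 (2.15 log units; beyond the scatter), against an 11-fold lower number from compound 2 to compound 3 (1.06 log units; beyond the scatter) for inverting the sec-butyl carbon alone. The change also removes the hydrogen-bond donor and the stereocentre of the leaving group and brings in 7 heavy atoms in place of 5, and this single step cannot tell these apart. What is known about configuration does not bear on this change of group.

On these data alone, it remains open whether the gain would hold with N-methyl-(sec-butyl)amino, diethylamino or dibutylamino at this position. Also open, as far as these compounds go, is how dipropylamino behaves with the opposite configuration at the remaining stereocentre.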